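The source may hold more compounds than are shown below. What is called first, only, known or untested is meant among the compounds shown, and "the series" means these compounds.

Working notes on the sulfonamide series.

In a functional assay on HPAC cells (Homo sapiens) for inhibition, read by MTT assay, with a stated time of 72 h (a lower number here means a stronger inhibitor of growth, a higher number a weaker inhibitor of growth), compound 3 `COc1cccc(CNCCCNS(=O)(=O)c2cc(C(F)(F)F)cc(C(F)(F)F)c2)c1` gives 2400 nM, the second highest of the three numbers recorded so far. Its nearest neighbour is compound 2 `O=S(=O)(NCCCCNCc1ccc(Br)cc1)c1cc(C(F)(F)F)cc(C(F)(F)F)c1`, which gives 2000 nM; the step of a 1.2-fold higher number from compound 2 to compound 3 (0.08 log units; within the scatter) is within the scatter. The furthest is compound 1 `CC(C)(C)c1ccc(CNCCNS(=O)(=O)c2cc(C(F)(F)F)cc(C(F)(F)F)c2)cc1`, which gives 14000 nM, a gap from compound 3 that lies beyond the scatter; compound 1 differs from compound 3 in more than one place, so only the two values themselves can be compared.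

Compound 4 `O=S(=O)(NCCCNCc1ccc(Cl)c(C(F)(F)F)c1)c1cc(C(F)(F)F)cc(C(F)(F)F)c1` is not yet measured. It differs from compound 3 by 4-chloro-3-(trifluoromethyl)phenyl in place of 3-methoxyphenyl on a saturated chain carbon bound to an amine nitrogen.

Among the measured compounds shown here, the only measured step that bears on this change is the aryl swap from compound 2 to compound 3, and that step was within the scatter. Replacing one benzyl aryl by another, with the shared core and chain length kept, has therefore so far left this assay essentially unchanged. Compound 2, which carries a halogenated aryl group, gives 2000 nM, and compound 4 also carries a halogenated aryl group.

On this basis compound 4 is expected to stay close to compound 3, with the step of a 1.3-fold lower number from compound 3 to compound 4 (0.12 log units; within the scatter) estimated to lie within the scatter. The estimate for compound 4 in this assay is 1800 nM, with a range from 700 nM to 4500 nM.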

Compound 4, concentration for 50% growth inhibition: 3000 nM
The estimate for compound 4 lay 1.7-fold (0.22 log units) below the measured number; the measured number falls inside the stated range.
By their numbers in this assay, from the lowest: compounds 2, 3 and 4 (each within the scatter of the next); then compound 1.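

In this assay, the exchange on a saturated chain carbon bound to an amine nitrogen gives a 1.3-fold higher number from compound 3 to compound 4 (0.10 log units; within the scatter). Unlike the earlier step from compound 2 to compound 3, which altered the chain together with the aryl group, this step leaves the chain as it is and changes only the aryl group, so the position tolerates 4-chloro-3-(trifluoromethyl)phenyl, with 11 heavy atoms and 0 hydrogen-bond acceptors, in place of 3-methoxyphenyl, with 8 heavy atoms and 1 hydrogen-bond acceptor, without a step beyond the scatter. No measurement at hand accounts for this outcome.

Still open is whether the position stays this tolerant with a carboxylic acid or a dimethylamino group on the aryl ring, since the aryl groups shown carry only halogen, trifluoromethyl, methoxy or tert-butyl substituents. Also open, as far as these compounds go, is what sets compound 1, at 14000 nM, apart from the others, as it differs from compound 3 in more than one place and no single change can be read from that gap.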